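The source may report more compounds than this note shows. Statements on the series, on what has been measured and on what is new or still open speak of the compounds shown alone.

In a functional assay on HepG2 cells (Homo sapiens) for antiproliferative activity, read by CCK-8 assay, with a stated time of 72 h (a higher number here means a weaker inhibitor, a lower number a stronger inhibitor), compound 1 (`Nc1ccccc1NC(=O)/C=C/c1ccc(COc2ccccc2)cc1`) gives > 32000 nM, which is a limit of the assay and not a number. On these data alone, its exact potency therefore remains unknown. Compound 2 (`CCc1ccc(OCc2ccc(C(=O)Nc3ccccc3N)cc2)cc1`) gives a measured number in this assay, at 6960 nM, but it differs from compound 1 in more than one place and so does not isolate any single change.

Compound 3 (`Nc1cnccc1NC(=O)/C=C/c1ccc(COc2ccccc2)cc1`) keeps the rest of compound 1 and alters one group: 3-aminopyridin-4-yl in place of 2-aminophenyl on an amide-type nitrogen. In words, 3-aminopyridin-4-yl stands in place of 2-aminophenyl on an amide-type nitrogen. Among the measured compounds shown here, no measured pair in this small set shows the effect of that exchange, so the expectation stays close to the starting point set by compound 1. The estimated at least 1.4-fold lower number from compound 1 to compound 3 (0.16 log units; that floor lies within the scatter) is a modest move towards stronger inhibition, and it may well not rise beyond the scatter. Compound 3 may also end up reported only as a limit. For compound 3 the expected value is 22000 nM, with an estimated range from 7000 nM to 60000 nM.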

Compound 3, half-maximal inhibitory concentration: > 32000 nM
Compound 3: a limit, no number; the forecaster's own chance of this, stated with the estimate: 55%; middle value at least 1.4-fold (0.16 log units) from the limit.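

No new step can be read from compound 1 to compound 3, because both results are limits of the assay and not numbers: the limit of > 32000 nM in this assay, at which 2 of the 3 values shown sit. The compounds shown leave open whether 3-aminopyridin-4-yl in place of 2-aminophenyl on an amide-type nitrogen changes potency at all, and by how much.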